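The compounds below may be only part of what the source reports. "The series", "measured", "known", "first", "only" and "open" are said of these compounds alone.

Compound 1 `Nc1nc(NCc2cccs2)nc2sc(-c3ccco3)nc12` gives 6.43 nM in an assay on CHO cells for displacement of a labelled ligand from adenosine receptor A3 (Homo sapiens), read by scintillation counting, with a stated time of 120 min; on this read-out higher numbers stand for weaker inhibition and lower numbers for stronger inhibition. Compound 2 `Nc1nc(NCc2ccccn2)nc2sc(-c3ccco3)nc12` gives 59 nM.

Within the data shown here, compound 2 stands at the higher of the two numbers; the only measured step is a 9.2-fold higher number from compound 1 to compound 2 (0.96 log units; beyond the scatter). Compound 3 `Nc1nc(NCc2cccnc2)nc2sc(-c3ccco3)nc12` differs from compound 2 by pyridin-3-yl in place of pyridin-2-yl on a saturated chain carbon bound to a nitrogen on an aromatic ring. Among the measured compounds shown here, no measured step bears on this exchange of one pyridinyl for another: the one known step concerns a thiophene ring replaced by a pyridine ring, a different kind of change. Compound 3 is therefore expected to show no step beyond the scatter, a 1.2-fold lower number from compound 2 to compound 3 (0.07 log units; within the scatter). The estimate for compound 3 is 50 nM, with a range from 15 nM to 200 nM.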

Compound 3, inhibition constant: 18.2 nM
Compound 3: the middle estimate sits 2.7-fold (0.44 log units) above what was measured; low and high end bracket the measured number.
By their numbers in this assay, from the lowest: compound 1; then compound 3; then compound 2.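

At this place, on a saturated chain carbon bound to a nitrogen on an aromatic ring, the same atoms joined differently change the result: pyridin-3-yl in place of pyridin-2-yl gives a 3.2-fold lower number from compound 2 to compound 3 (0.51 log units; beyond the scatter), so the two pyridinyl groups cannot be treated as one. Thiophen-2-yl still keeps the lowest number, with a 2.8-fold higher number from compound 1 to compound 3 (0.45 log units; beyond the scatter), so pyridin-3-yl closes only part of the gap left by pyridin-2-yl. Nothing available explains the difference between the two pyridinyl groups.

On these data alone, whether a phenyl ring or a longer chain at this place would fall nearer to thiophen-2-yl or to the pyridinyl groups remains open.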